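Removing One Methoxy Group From a Trimethoxyphenyl Pyrazole Chalcone

A few compounds are considered here, and "the series" means these few. Any claim that something is new, unique, unknown or untested is made for them only; others in the source may bear on it.

Measured compounds:
compound 1, `COc1cc(-c2cc(/C=C/C(=O)c3ccc(N)cc3)[nH]n2)cc(OC)c1OC`, 85%
compound 2, `COc1cc(-c2cc(/C=C/C(=O)c3ccc(Cl)c(Cl)c3)[nH]n2)cc(OC)c1OC`, 87%

Compound 1 was tested in a functional assay on T47D cells (Homo sapiens) for cytotoxicity, read by sulforhodamine B assay, with a stated time of 48 h, tested at 0.1 uM (a higher number here means a weaker effect of the compound at the concentration tested, a lower number a stronger effect), where compound 1 gives 85%. Its only measured companion, compound 2, gives 87%, and the two numbers lie within the scatter of each other; a number 2 percentage points higher from compound 1 to compound 2 (within the scatter). Among the measured compounds shown here, compound 1 therefore stands with a single neighbour, and no step from it is beyond the scatter.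

Compound 3, `COc1ccc(-c2cc(/C=C/C(=O)c3ccc(N)cc3)[nH]n2)cc1OC`, differs from compound 1 at a different place from that step: hydrogen in place of methoxy on an aromatic carbon. For the measured compounds named here, the one measured step, between compound 1 and compound 2, changes the group on the carbonyl carbon and says nothing about the methoxy groups on the other ring. Going by the values given here, there is thus no measured step that bears directly on this change, and the expectation rests only on the closeness of compound 1 and compound 2.

Compound 3 is expected to give about 84% in this assay, within the range 68% to 97%, an estimated step of a number 1 percentage points lower from compound 1 to compound 3 (within the scatter), not beyond the scatter.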

Compound 3, a percentage reported as activity, at one concentration (the size of the read-out at that concentration, not a potency): 90%
Beside the measured number, compound 3's estimate is 6 percentage points below it, and the stated range covers the measured number.
By their numbers in this assay, from the lowest: compounds 1, 2 and 3 (each within the scatter of the next).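

In this assay, putting hydrogen in place of methoxy on an aromatic carbon, at the place ortho to a methoxy group and meta to a large group, gives a number 5 percentage points higher from compound 1 to compound 3 (within the scatter) with the 4-aminophenyl group held fixed. Among the compounds shown here, this is the first measured step at the methoxy-bearing ring, and like the step on the carbonyl carbon it stays within the scatter, so this read-out at the one concentration used does not separate the compound with the methoxy group from the one without it. Nothing available gives a reason for this result.

From the compounds shown here alone, whether a hydroxy group, an ethoxy group or a chlorine atom in that place would read the same remains open. Also open, going by these compounds, is whether the same change would read alike with 3,4-dichlorophenyl on the carbonyl carbon, or at other concentrations.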